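Changing the Amine Group on a Ring Nitrogen

The source may report more compounds than this note shows. Statements on the series, on what has been measured and on what is new or still open speak of the compounds shown alone.

Compound 2 `CCN1CCC(N2CCN(C(=O)COCCN(C)S(=O)(=O)c3c(C)cc(OC)cc3C)CC2)CC1` and compound 1 `COc1cc(C)c(S(=O)(=O)N(C)CCOCC(=O)N2CCN(C3CCN(C4CC4)CC3)CC2)c(C)c1` share the same core and differ only in the group on an amine nitrogen in a ring. In an assay on HEK293 cells for displacement of a labelled ligand from B1 bradykinin receptor (Homo sapiens), read by scintillation counting (on this read-out higher numbers stand for weaker inhibition and lower numbers for stronger inhibition), compound 1 gives 0.8 nM, and in this assay compound 2 gives 0.2 nM. Among the measured compounds shown here, the step of a 4.0-fold lower number from compound 1 to compound 2 (0.60 log units; beyond the scatter) is the only measured change, and it leaves compound 2 with the lowest of the two numbers obtained so far. Compound 3 `COc1cc(C)c(S(=O)(=O)N(C)CCOCC(=O)N2CCN([C@H]3CN4CCC3CC4)CC2)c(C)c1` has not yet been measured. It differs from compound 2 in this way: a group of 8 heavy atoms (7 carbon, 1 nitrogen; 2 six-membered non-aromatic rings with 1 hetero atom each) in place of a group of 8 heavy atoms (7 carbon, 1 nitrogen; one six-membered non-aromatic ring with 1 hetero atom), on an amine nitrogen in a ring. For the measured compounds named here, no measured step covers this kind of exchange; the step from compound 1 to compound 2 concerns a different, smaller group on the same nitrogen and shows only that this position can move the number by a modest amount. Going by the values given here, with no closer precedent, the exchange is expected to give a modest move toward a higher number, a 2.5-fold higher number from compound 2 to compound 3 (0.40 log units; beyond the scatter). Compound 3 is accordingly estimated at 0.5 nM in this assay, with a plausible range from 0.15 nM to 2 nM.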

Compound 3, inhibition constant: 34 nM
Compound 3: middle estimate off by 68-fold (1.83 log units), on the low side, outside the stated range (above it).
By their numbers in this assay, from the lowest: compound 2; then compound 1; then compound 3.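

In this assay, among the compounds shown here, putting the group with 2 six-membered non-aromatic rings in place of 1-ethylpiperidin-4-yl gives a 170-fold higher number from compound 2 to compound 3 (2.23 log units; beyond the scatter) and places this position in a different range of sensitivity, since the only earlier change here was the modest 4.0-fold lower number from compound 1 to compound 2 (0.60 log units; beyond the scatter) in the same assay. The comparison with the cyclopropyl-bearing group of compound 1 points the same way, with a 43-fold higher number from compound 1 to compound 3 (1.63 log units; beyond the scatter) as a second large step, so compound 3 stands apart from both compounds that carry a single six-membered ring with a group on its nitrogen. The groups compared in the first step match in heavy atoms, donors, acceptors and net charge, so those counts alone do not settle the number at this position, and no supporting measurement bears on the reason for the large move.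

The compounds shown leave open whether the step belongs to the two-ring group as such or to its single defined stereocentre, which only the opposite stereoisomer of that group could separate. They also leave open how far the trend from cyclopropyl to ethyl extends, for instance to a methyl or an isopropyl on the same ring nitrogen.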